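The source may report more compounds than this note shows. Statements on the series, on what has been measured and on what is new or still open speak of the compounds shown alone.

Compound 1 `OC(CCCN1CCN(c2ncc(F)cn2)CC1)C1CCCCC1` gives 12 nM in an assay (Cavia porcellus) for displacement of a labelled ligand from Sigma non-opioid intracellular receptor 1 (Homo sapiens); a lower number here means a stronger inhibitor, a higher number a weaker inhibitor.
Compound 2 `OC(CCCN1CCN(c2ncc(F)cn2)CC1)c1ccc(F)c2ccccc12` gives 88 nM in this assay.
Compound 3 `NC(CCCN1CCN(c2ncc(F)cn2)CC1)C1CCCCC1` gives 52 nM in this assay.

Compound 4 `NC(CCCN1CCN(c2ncc(F)cn2)CC1)c1ccc(F)c2ccccc12` is not yet measured. It differs from compound 2 by amino in place of hydroxy on a saturated chain carbon bound to an aromatic carbon and a saturated chain carbon. The same kind of change is already seen once: compound 3 differs from compound 1 by amino in place of hydroxy on a saturated chain carbon bound to a saturated chain carbon and a saturated ring carbon, and that step gave a 4.3-fold higher number from compound 1 to compound 3 (0.64 log units; beyond the scatter). The two places are not identical, since in compound 1 the carbon is bound to a saturated chain carbon and a saturated ring carbon, whereas in compound 2 it is bound to an aromatic carbon and a saturated chain carbon. The difference between the two cores is not broken down here. For compound 2 to compound 4 the account expects a step of a 4.0-fold higher number from compound 2 to compound 4 (0.60 log units; beyond the scatter), resting on the earlier step of a 4.3-fold higher number from compound 1 to compound 3 (0.64 log units; beyond the scatter). Compound 4 is therefore estimated at 350 nM, between 120 nM and 1000 nM.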

Compound 4, half-maximal inhibitory concentration: 215 nM
For compound 4 the middle estimate is 1.6-fold (0.21 log units) above the measured one, and the stated range covers the measured number.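

In this assay the new step is a 2.4-fold higher number from compound 2 to compound 4 (0.39 log units; beyond the scatter) and runs the same way as the earlier one, so amino in place of hydroxy gives a higher number on both cores, and the two steps do not differ beyond the scatter: the same change on two cores in this assay, a 4.3-fold higher number (0.64 log units; beyond the scatter) from compound 1 to compound 3 and a 2.4-fold higher number (0.39 log units; beyond the scatter) from compound 2 to compound 4, 1.8-fold (0.25 log units) apart, within the scatter of two such steps

On these two cores, then, the change carries over in direction and in roughly its size. Two cores are too few to show that it would carry to any other core in the series, and these numbers do not say what lies behind the step.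

The compounds shown leave open how a methoxy or a dimethylamino group would compare with hydroxy and amino at this place. They also leave open whether a longer chain would alter the step.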